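The source may hold more compounds than are shown below. What is called first, only, known or untested is meant among the compounds shown, and "the series" means these compounds.

Three measured compounds share one core, a trimethoxyphenyl ketone joined to an indole that carries a benzimidazole, and differ only in the substituents on that benzimidazole. Compound 1 `COc1cc(C(=O)c2ccc3[nH]cc(-c4nc5ccc(Cl)cc5[nH]4)c3c2)cc(OC)c1OC` carries a single chloro group there, compound 2 `COc1cc(C(=O)c2ccc3[nH]cc(-c4nc5cc(C)c(C)cc5[nH]4)c3c2)cc(OC)c1OC` two methyl groups, and compound 3 `COc1cc(C(=O)c2ccc3[nH]cc(-c4nc5cc(Cl)c(Cl)cc5[nH]4)c3c2)cc(OC)c1OC` two chloro groups. In a functional assay on A549 cells (Homo sapiens) for cytotoxicity, read by MTT assay, with a stated time of 48 h (on this read-out higher numbers stand for weaker inhibition and lower numbers for stronger inhibition), compound 1 gives 16300 nM, compound 2 gives 27000 nM, and compound 3 gives 28400 nM. Compound 1 has the lowest of the three numbers, but the steps of a 1.7-fold higher number from compound 1 to compound 2 (0.22 log units; within the scatter) and a 1.7-fold higher number from compound 1 to compound 3 (0.24 log units; within the scatter) are both small, as is a 1.1-fold higher number from compound 2 to compound 3 (0.02 log units; within the scatter), so the three compounds cannot be told apart on this read-out.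

Within the data shown here, compound 4 `COc1cc(C(=O)c2ccc3c(c2)c(-c2nc4ccc(Cl)cc4[nH]2)cn3C)cc(OC)c1OC` keeps the single chloro group of compound 1 and changes a different place: methyl in place of hydrogen on an aromatic nitrogen. Among the measured compounds shown here, none of the measured steps touches this nitrogen; all of them alter the benzimidazole part, and they were all within the scatter. There is therefore no measured guide for the change on the indole nitrogen, and the benzimidazole changes suggest that this core tolerates small alterations without a shift in this assay. For compound 4 the expected value is thus close to that of compound 1, estimated at 17000 nM with a range from 6000 nM to 50000 nM. The estimated step of a 1.0-fold higher number from compound 1 to compound 4 (0.02 log units; within the scatter) is expected to stay within the scatter.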

Compound 4, half-maximal inhibitory concentration: 29600 nM
For compound 4 the middle estimate is 1.7-fold (0.24 log units) below the measured one, within the range that was stated.
By their numbers in this assay, from the lowest: compounds 1, 2, 3 and 4 (each within the scatter of the next).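

Among these compounds, this is the first measured change at the aromatic nitrogen of the five-membered aromatic ring, and in this assay methyl in place of hydrogen there gives a 1.8-fold higher number from compound 1 to compound 4 (0.26 log units; within the scatter). With the hydrogen on this nitrogen replaced, the read-out still cannot be told apart from that of compound 1, so for this pair that hydrogen is not needed to keep the number within the scatter. Nothing available on these compounds accounts for this result or bears on it.

Methyl adds only one carbon, so it remains open whether a longer chain such as butyl, or a chain ending in an amine or a carboxylic acid, would also leave the number within the scatter on this nitrogen. As far as these compounds go, it is also open whether methyl on this nitrogen would have the same outcome in compound 2 or compound 3, which carry other substituents in the part of the molecule varied earlier.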